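From Cyclopropyl to Benzyl on the Amide

The source may report more compounds than this note shows. Statements on the series, on what has been measured and on what is new or still open speak of the compounds shown alone.

In a functional assay on HUVEC cells (Homo sapiens) for antiproliferative activity (a lower number here means a stronger inhibitor, a higher number a weaker inhibitor), compound 1 `CNC(=O)c1cccc(CSc2cnc(Nc3ccccn3)s2)c1` gives "not determined" (no result reported). For the measured compounds named here, compound 2 `O=C(NC1CC1)c1ccc(F)c(NCc2cnc(Nc3ccccn3)s2)c1` gives 14 nM, the only number available, so it cannot be ranked against another compound. Compound 3 `O=C(NCc1ccccc1)c1ccc(F)c(NCc2cnc(Nc3ccccn3)s2)c1` has benzyl in place of cyclopropyl on an amide-type nitrogen. Going by the values given here, no measured pair shows what such a change does in this assay, so any expectation remains tentative. A modest weakening is expected, with the estimated step being a 2.5-fold higher number from compound 2 to compound 3 (0.40 log units; beyond the scatter). For compound 3, the estimated value is 35 nM, with an expected range of 9 nM to 140 nM.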

Compound 3, half-maximal inhibitory concentration: 120 nM
Estimate against measurement, compound 3: 3.4-fold (0.54 log units) below; measured number inside the range.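

In this assay, for the compounds shown here, the amide-type nitrogen proves sensitive to its substituent: benzyl in place of cyclopropyl gives an 8.6-fold higher number from compound 2 to compound 3 (0.93 log units; beyond the scatter) in the first measured step at this position. Going by these compounds alone, the change therefore costs activity here rather than leaving it unchanged, although the single pair shows this for benzyl alone. Nothing available bears on the reason for this loss.

Whether the aromatic ring or the added heavy atoms account for the step remains open. So does how an ethyl group, a longer phenethyl chain or a chain ending in an amine would behave on this nitrogen.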